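A few compounds are considered here, and "the series" means these few. Any claim that something is new, unique, unknown or untested is made for them only; others in the source may bear on it.

Measured in an ADME assay on TERT-RPE1 cells (Homo sapiens) for cytotoxicity, read by MTT assay, with a stated time of 72 h; a higher number here means a weaker inhibitor, a lower number a stronger inhibitor:
- Compound 1 `C=CC/N=C1\S/C(=C\c2ccc(OC)cc2)C(=O)N1C`: > 100000 nM (a limit)
- Compound 2 `C=C1CN(C)/C(=N/c2ccccc2)S1`: > 100000 nM (a limit)
- Compound 3 `COc1ccc(/C=C2/CN(C)/C(=N/c3ccc(OC)cc3)S2)cc1`: 65900 nM

Compound 1 gives only a limit and not a number: it stands at the limit of > 100000 nM in this assay, at which 2 of the 3 values shown sit. The next compound to be tested, compound 4 `COc1ccc(/C=C2\S/C(=N\c3ccc(C)c(Cl)c3)N(C)C2=O)cc1`, keeps the core of compound 1 but has 3-chloro-4-methylphenyl in place of allyl on a double-bonded nitrogen.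

Among the measured compounds shown here, no measured pair shows this change, so any expectation is a rough one. Compound 3 has an aromatic ring on a double-bonded nitrogen and gives a real number, 65900 nM. Compound 2 also has an aromatic ring there, yet it gives > 100000 nM, which is a limit. The evidence therefore points only weakly towards a lower number in this assay. A modest move in that direction is expected, and the assay may again report only a limit. The expected step of an at least 1.6-fold lower number from compound 1 to compound 4 (0.22 log units; that floor lies within the scatter) is an estimate resting on the value of compound 3 at 65900 nM. For compound 4 the estimated value is 60000 nM, with an expected range from 20000 nM to 100000 nM.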

Compound 4, half-maximal inhibitory concentration: 23000 nM
The estimate for compound 4 lay 2.6-fold (0.42 log units) above the measured number, within the range that was stated.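

Replacing allyl with 3-chloro-4-methylphenyl on a double-bonded nitrogen, with the rest of the molecule unchanged, can be read directly in this assay, and it gives an at least 4.3-fold lower number from compound 1 to compound 4 (0.63 log units; beyond the scatter). Compound 1 stands at a limit and not at a number: the limit of > 100000 nM in this assay, at which 2 of the 4 values shown sit. Compound 4 gives 23000 nM, a true number. From the compounds shown here alone, the step therefore lies beyond the usual scatter, its full size is unknown, and this one place on the core of compound 1 is enough to make the compound a clearly stronger inhibitor in this assay.

Going by these compounds, this single pair cannot separate the contribution of the aromatic ring itself from that of its chlorine or its methyl group, so it remains open whether a plain phenyl ring on this same core would give a similar number. It also leaves open what a longer carbon chain, or a phenyl ring carrying an amine or a carboxylic acid, would do in this place, and whether the number would rise or fall further.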